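Dropping one chlorine from a dichlorinated fused core

The source may report more compounds than this note shows. Statements on the series, on what has been measured and on what is new or still open speak of the compounds shown alone.

Measured: compound 1 `ClCc1ccc(Cn2cnc3nc(Cl)nc(Cl)c32)cc1` with 83200 nM; compound 2 `ClCc1ccccc1Cn1cnc2nc(Cl)nc(Cl)c21` with > 100000 nM.

Going by the values given here, in a functional assay on MCF7 cells (Homo sapiens) for cytotoxicity, read by sulforhodamine B assay, with a stated time of 48 h (a lower number here means that less compound is tolerated, a higher number that more compound is tolerated), compound 1 gives 83200 nM, the only number among the two results. For compound 2 the assay reports only > 100000 nM, which is a limit and not a number (the limit of > 100000 nM in this assay, at which 1 of the 2 values shown sits). Compound 3 `ClCc1ccc(Cn2cnc3ncnc(Cl)c32)cc1` differs from compound 1 by hydrogen in place of chloro on an aromatic carbon. Among the compounds with values here, no step between measured compounds is available, so the direction of the step from compound 1 to compound 3 is expected to be small, near the scatter, or toward less potency. Compound 3 is expected at 120000 nM, in the range 50000 nM to 300000 nM, with a fair chance the assay reports only a limit, a step of a 1.4-fold higher number from compound 1 to compound 3 (0.16 log units; within the scatter).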

Compound 3, concentration lethal to 50% of the cells: 6450 nM
Estimate against measurement, compound 3: 19-fold (1.27 log units) above; measured number outside the range, below it.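

In this assay, the chloro group on the aromatic carbon between two ring nitrogen atoms proves far from neutral: hydrogen in its place gives a 13-fold lower number from compound 1 to compound 3 (1.11 log units; beyond the scatter), a large step. This position therefore has a strong bearing on the read-out, and removing this one chlorine leaves the cells tolerating much less compound. The data shown give no reason for the step.

Only chloro and hydrogen are shown at this carbon, so what an amine or a methoxy group would give there stays open. Going by these compounds, whether the same step would appear on the framework of compound 2 also stays open.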